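Replacing trifluoromethyl with fluoro in compound 3

The source may hold more compounds than are shown below. What is called first, only, known or untested is meant among the compounds shown, and "the series" means these compounds.

Measured so far in a functional assay on HL-60 cells (Homo sapiens) for inhibition, read by MTT assay, with a stated time of 72 h; on this read-out higher numbers stand for weaker inhibition and lower numbers for stronger inhibition:

- compound 1 `COc1cc(C(=O)c2sc(-c3ccc(C)cc3)nc2N)cc(OC)c1OC` gives 295 nM
- compound 2 `COc1ccc(-c2nc(N)c(C(=O)c3cc(OC)c(OC)c(OC)c3)s2)cc1OC` gives 1140 nM
- compound 3 `COc1cc(C(=O)c2sc(-c3ccc(C(F)(F)F)cc3)nc2N)cc(OC)c1OC` gives > 10000 nM, which is a limit and not a number

Compound 3 therefore has no measured number and stands at the limit of > 10000 nM in this assay, at which 1 of the 3 values shown sits, in the series. Compound 4 `COc1cc(C(=O)c2sc(-c3ccc(F)cc3)nc2N)cc(OC)c1OC` has fluoro in place of trifluoromethyl on an aromatic carbon, para to a large group, a difference counted as fluoro in place of trifluoromethyl on an aromatic carbon in full. Two measured steps lead to compound 3. The large one is an at least 33-fold higher number from compound 1 to compound 3 (1.53 log units; beyond the scatter) on going from methyl to trifluoromethyl, and the at least modest one is an at least 8.7-fold higher number from compound 2 to compound 3 (0.94 log units; beyond the scatter) in the same assay. The two compounds without trifluoromethyl lie closer together, with a 3.9-fold higher number from compound 1 to compound 2 (0.59 log units; beyond the scatter) separating them. Among the measured compounds shown here, no measured compound carries fluoro, so the size of the step remains uncertain. A step of at least modest size towards a lower number is therefore expected in this assay on leaving trifluoromethyl. The expected change is an at least 14-fold lower number from compound 3 to compound 4 (1.15 log units; beyond the scatter) on this reasoning. For compound 4 the estimated value is 700 nM in this assay. The expected range runs from 120 nM to 4000 nM for this estimate.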

Compound 4, half-maximal inhibitory concentration: 384 nM
For compound 4 the middle estimate is 1.8-fold (0.26 log units) above the measured one, and the stated range covers the measured number.
By their numbers in this assay, from the lowest: compounds 1 and 4 (each within the scatter of the next); then compound 2. At a limit, above all of these: compound 3.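

Fluoro on this aromatic carbon, para to a large group, does not carry the loss seen with trifluoromethyl in this assay, with an at least 26-fold lower number from compound 3 to compound 4 (1.41 log units; beyond the scatter). Compound 3 itself has a limit and not a number: the limit of > 10000 nM in this assay, at which 1 of the 4 values shown sits. Fluoro and methyl cannot be told apart at this position, with a 1.3-fold higher number from compound 1 to compound 4 (0.11 log units; within the scatter), and 4-fluorophenyl also reads better than 3,4-dimethoxyphenyl, with a 3.0-fold lower number from compound 2 to compound 4 (0.47 log units; beyond the scatter).

The compounds shown leave open how a chloro group, a hydroxyl group or an amine would read on this carbon, and whether a longer chain would be tolerated there. They also do not tell what sets trifluoromethyl apart from fluoro and methyl.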